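Swapping a methoxyphenyl for benzyl on the shared core

A few compounds are considered here, and "the series" means these few. Any claim that something is new, unique, unknown or untested is made for them only; others in the source may bear on it.

In an assay on Sf9 cells for inhibition of serine/threonine-protein kinase 4 (Homo sapiens), read by luminescence and ADP-Glo, with a stated time of 1 h, in the presence of a further agent that is not named here (a higher number here means a weaker inhibitor, a lower number a stronger inhibitor), compound 3 `COc1ccccc1C1C(=O)N(C)c2cnc(Nc3ccc(S(N)(=O)=O)cc3)nc2N1C` gives 251 nM. Compound 1 `CCCC1C(=O)N(C)c2cnc(Nc3ccc(S(N)(=O)=O)cc3)nc2N1C` gives 206 nM in this assay, and compound 2 `CN1C(=O)C(c2cccc(Cl)c2)N(C)c2nc(Nc3ccc(S(N)(=O)=O)cc3)ncc21` gives 989 nM. For the measured compounds named here, compound 3 thus sits within the scatter of compound 1, and only the step of a 3.9-fold lower number from compound 2 to compound 3 (0.60 log units; beyond the scatter) lies beyond it. Compound 4 `CN1C(=O)C(Cc2ccccc2)N(C)c2nc(Nc3ccc(S(N)(=O)=O)cc3)ncc21` carries benzyl in place of 2-methoxyphenyl on a saturated ring carbon. Going by the values given here, two measured steps bear on this: a 1.2-fold higher number from compound 1 to compound 3 (0.09 log units; within the scatter), and a 4.8-fold higher number from compound 1 to compound 2 (0.68 log units; beyond the scatter). A flexible chain and the methoxyphenyl gave near-identical numbers, while a chlorophenyl moved the number upward; benzyl, a chain ending in a plain ring, is expected to behave like the chain. The expected step is a 1.2-fold higher number from compound 3 to compound 4 (0.08 log units; within the scatter). Compound 4 is estimated at 300 nM, within 120 nM to 800 nM.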

Compound 4, half-maximal inhibitory concentration: > 10000 nM
Compound 4: no number, only a limit (the forecaster's own chance of this, stated with the estimate: 3%); at least 33-fold (1.52 log units) between middle value and limit.
By their numbers in this assay, from the lowest: compounds 1 and 3 (each within the scatter of the next); then compound 2. At a limit, above all of these: compound 4.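

Compound 4 gives no number, only a limit of the assay: the limit of > 10000 nM in this assay, at which 1 of the 4 values shown sits.

For the compounds shown here, the steps of an at least 39-fold higher number from compound 3 to compound 4 (1.60 log units; beyond the scatter), an at least 10-fold higher number from compound 2 to compound 4 (1.00 log units; beyond the scatter) and an at least 48-fold higher number from compound 1 to compound 4 (1.68 log units; beyond the scatter) show that this saturated ring carbon is far less forgiving than the earlier compounds suggested. Benzyl parts from propyl and from both substituted phenyl groups, so neither a chain nor a ring on this carbon predicts what a chain ending in a ring will do.

What the data cannot tell is why benzyl behaves this way. Going by these compounds, whether unsubstituted phenyl, phenethyl or a benzyl carrying a methoxy group would give a measurable number stays open.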